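Swapping one ring group on the double-bonded chain carbon

The source may hold more compounds than are shown below. What is called first, only, known or untested is meant among the compounds shown, and "the series" means these compounds.

compound 1 `O=C(/C(=C\c1csc([N+](=O)[O-])c1)S(=O)(=O)c1ccc(Br)cc1)c1ccc(Br)cc1`: 1000 nM
compound 2 `O=C(/C(=C\c1ccc(F)cc1)S(=O)(=O)c1ccc(Br)cc1)c1ccc(Br)cc1`: 4000 nM

In a functional assay on DU-145 cells (Homo sapiens) for inhibition, read by trypan blue exclusion, with a stated time of 96 h (on this read-out lower numbers stand for stronger inhibition of growth and higher numbers for weaker inhibition of growth), compound 2 gives 4000 nM, the higher of the two numbers and so the weaker inhibition of growth. Compound 3 `Nc1c(Br)cc(Br)cc1/C=C(\C(=O)c1ccc(Br)cc1)S(=O)(=O)c1ccc(Br)cc1` keeps the shared core and changes one group: 2-amino-3,5-dibromophenyl in place of 4-fluorophenyl on a double-bonded chain carbon bound to a double-bonded chain carbon. Among the measured compounds shown here, only one measured step touches this place, a 4.0-fold higher number from compound 1 to compound 2 (0.60 log units; beyond the scatter), and it involves different groups, so it is a loose guide. Resting on that modest step, a change of similar size is expected, more likely toward a lower number than a higher one. The expected step is a 2.0-fold lower number from compound 2 to compound 3 (0.30 log units; within the scatter). For compound 3 the estimated value is 2000 nM, with an expected range of 500 nM to 8000 nM.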

Compound 3, concentration for 50% growth inhibition: 25000 nM
Estimate against measurement, compound 3: 13-fold (1.10 log units) below; the measured number lies above the stated range.
By their numbers in this assay, from the lowest: compound 1; then compound 2; then compound 3.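

At this place on the double-bonded chain carbon, the ring group can shift the result far more than the first pair showed. In this assay, 2-amino-3,5-dibromophenyl weakens growth inhibition against 4-fluorophenyl (a 6.3-fold higher number from compound 2 to compound 3 (0.80 log units; beyond the scatter)) and even more against 5-nitrothiophen-3-yl (a 25-fold higher number from compound 1 to compound 3 (1.40 log units; beyond the scatter)). Nothing available accounts for this loss.

The compounds shown cannot separate the amine from the two bromines, as neither a 2-aminophenyl nor a 3,5-dibromophenyl group appears among them. As far as these compounds go, how a plain phenyl or a pyridine ring would fare here also stays open.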